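A Bromo Substituent Added to a Compound at the Assay Limit

This account rests on a few compounds, and the source may have more. Where it says the series, first, only, none or still open, it means among the compounds named here.

Compound 1 `COc1cc(OC)c2c(=O)cc(/C=C/c3ccccc3)oc2c1` in a functional assay on PC-3 cells (Homo sapiens) for antiproliferative activity, read by MTT assay, with a stated time of 12 h (a higher number here means a weaker inhibitor, a lower number a stronger inhibitor), gives > 40000 nM, which is a limit of the assay rather than a number.
Compound 2 `COc1ccc(/C=C/c2cc(=O)c3c(OC)cc(OC)cc3o2)cc1` in this assay gives > 40000 nM, again a limit only.

Going by the values given here, compound 1 therefore stands at the limit, as does the one further value shown (the limit of > 40000 nM in this assay, at which 2 of the 2 values shown sit). Among the compounds with values here, the only measured step, a step that the two limits leave unreadable from compound 1 to compound 2, cannot be sized because both of its ends are limits. Compound 3 `COc1cc(OC)c2c(=O)cc(/C=C/c3ccc(Br)cc3)oc2c1` carries bromo in place of hydrogen on an aromatic carbon. Within the data shown here, no measured step resembles this change, and nothing here moves off the limit. The expected step is a number no higher from compound 1 to compound 3 (the limit leaves the size open), essentially none. Compound 3 is estimated at 40000 nM, within a range from 12000 nM to 130000 nM.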

Compound 3, half-maximal inhibitory concentration: > 40000 nM
Compound 3 was reported as a limit; the forecaster's own chance of this, stated with the estimate: 70%; the middle value lies on the limit itself.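

Compound 3 stands at the same limit as compound 1 and compound 2, so no step among the three can be read: the limit of > 40000 nM in this assay, at which 3 of the 3 values shown sit.

The compounds shown leave open whether bromo or methoxy changes the activity at all in this assay.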